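This account rests on a few compounds, and the source may have more. Where it says the series, first, only, none or still open, it means among the compounds named here.

Compound 1, `CC(C)(C)C#Cc1cc(N(C(=O)[C@H]2CC[C@H](C)CC2)[C@H]2CC[C@@H](Oc3ccc(=O)[nH]n3)CC2)c(C(=O)O)s1` — in an ADME assay on MT4 cells (Homo sapiens) for cytotoxicity, with a stated time of 5 days (on this read-out lower numbers stand for higher toxicity in this test and higher numbers for lower toxicity in this test), compound 1 gives > 20000 nM, which is a limit of the assay and not a number.
Compound 2, `CC(C)(C)C#Cc1cc(N(C(=O)[C@H]2CC[C@H](C)CC2)[C@H]2CC[C@@H](Oc3cccnc3)CC2)c(C(=O)O)s1` — compound 2 gives > 20000 nM, again a limit rather than a number.
Compound 3, `CC(C)N(c1cc(C#CC(C)(C)C)sc1C(=O)O)C(=O)[C@H]1CC[C@H](Cl)CC1` — compound 3 gives > 20000 nM, also a limit and not a number.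

Because all three values are limits, the step that the two limits leave unreadable from compound 1 to compound 2 cannot be read. Among the measured compounds shown here, compound 3 stands exactly where the other two stand: at the limit described by the limit of > 20000 nM in this assay, at which 3 of the 3 values shown sit, so no compound shows measurable toxicity in this assay.

Compound 4, `CC(C)N(c1cc(C#CC(C)(C)C)sc1C(=O)O)C(=O)[C@H]1CC[C@H](CF)CC1`, differs from compound 3 in one place: fluoromethyl in place of chloro on a saturated ring carbon. For the measured compounds named here, no measured step tests this change; the only recorded step, from compound 1 to compound 2, alters a different part of the molecule and is itself unreadable. The expectation for compound 4 therefore rests on compound 3 sitting at the limit with > 20000 nM and on (the limit of > 20000 nM in this assay, at which 3 of the 3 values shown sit). The estimated step that the limit leaves unreadable from compound 3 to compound 4 is none beyond the scatter. Compound 4 is expected to give 40000 nM, between 15000 nM and 150000 nM, most likely reported again only as a limit.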

Compound 4, half-maximal cytotoxic concentration: > 20000 nM
Compound 4: only a limit was reported (the forecaster's own chance of this, stated with the estimate: 85%); the middle value lies beyond the limit too.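

Among the compounds shown here, compound 3 and compound 4 both give only a limit of the assay and not a number, so no step between them can be read: the limit of > 20000 nM in this assay, at which 4 of the 4 values shown sit.

The compounds shown leave open how far any of them lies past that limit in this assay and whether fluoromethyl and chloro differ there at all.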